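Amide Variation on a Shared Core: Estimating Compound 4

This account rests on a few compounds, and the source may have more. Where it says the series, first, only, none or still open, it means among the compounds named here.

Compound 1 `CC(=O)N(C)c1ccc2[nH]c(-c3n[nH]c4ccccc34)cc2n1`: 10300 nM
Compound 2 `CCC(=O)N(C)c1ccc2[nH]c(-c3n[nH]c4ccccc34)cc2n1`: 9300 nM
Compound 3 `CN(C(=O)CCc1ccccc1)c1ccc2[nH]c(-c3n[nH]c4ccccc34)cc2n1`: 7380 nM

These three compounds share one core and differ only in the group on the amide carbonyl, all measured in a functional assay on KB cells (Homo sapiens) for antiproliferative activity, read by MTT assay, with a stated time of 72 h; on this read-out lower numbers stand for stronger inhibition and higher numbers for weaker inhibition. Compound 3 gives the lowest of the three numbers, but the steps of a 1.3-fold lower number from compound 2 to compound 3 (0.10 log units; within the scatter) and a 1.4-fold lower number from compound 1 to compound 3 (0.14 log units; within the scatter) are within the scatter, as is a 1.1-fold lower number from compound 1 to compound 2 (0.04 log units; within the scatter); the three compounds cannot be ranked.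

Compound 4 `CN(C(=O)c1ccc(Cl)cc1)c1ccc2[nH]c(-c3n[nH]c4ccccc34)cc2n1` differs from compound 3 by 4-chlorophenyl in place of phenethyl on a carbonyl carbon. The measured steps each alter a saturated chain on the carbonyl; none places an aromatic ring directly on it, so they bear on this change only loosely, and all stayed within the scatter. No step beyond the scatter is therefore expected in this assay. Compound 4 is estimated at 7500 nM, with a range from 3000 nM to 19000 nM, an expected step of a 1.0-fold higher number from compound 3 to compound 4 (0.01 log units; within the scatter).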

Compound 4, half-maximal inhibitory concentration: 630 nM
The estimate for compound 4 lay 12-fold (1.08 log units) above the measured number, and the stated range ends above it.
By their numbers in this assay, from the lowest: compound 4; then compounds 3, 2 and 1 (each within the scatter of the next).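

In this assay the group on the carbonyl carbon can shift the number strongly: 4-chlorophenyl gives a 12-fold lower number from compound 3 to compound 4 (1.07 log units; beyond the scatter) and a 15-fold lower number from compound 2 to compound 4 (1.17 log units; beyond the scatter) and also a 16-fold lower number from compound 1 to compound 4 (1.21 log units; beyond the scatter) against the saturated chains. Those chains had differed only within the scatter, so this position responds to a change of group once an aromatic ring sits directly on the carbonyl carbon. Nothing measured here explains the size of these steps. The compounds shown do not separate the effect of the directly attached ring from that of its chlorine. Phenyl, 4-fluorophenyl or 4-methoxyphenyl on the same carbonyl carbon remains an open comparison.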